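Methoxy to hydroxy on the side chain of compound 2

The source may hold more compounds than are shown below. What is called first, only, known or untested is meant among the compounds shown, and "the series" means these compounds.

Of the compounds shown here, two have been measured so far. In a functional assay on A2780 cells (Homo sapiens) for antiproliferative activity, read by MTT assay, with a stated time of 48 h (a higher number here means a weaker inhibitor, a lower number a stronger inhibitor), compound 1 `COc1ccc(C(=O)c2cc(OC)c(OC)c(OC)c2)c(NC(=O)CO)c1` gives 100 nM, and compound 2 `C=C(c1cc(OC)c(OC)c(OC)c1)c1ccc(OC)c(O)c1NC(=O)COC` gives 450 nM, the higher of the two numbers and a gap beyond the scatter. Compound 3 `C=C(c1cc(OC)c(OC)c(OC)c1)c1ccc(OC)c(O)c1NC(=O)CO` arises from compound 2 by a single change, methoxymethyl to hydroxymethyl: hydrogen in place of methyl on an oxygen on a saturated carbon. For the measured compounds named here, no measured pair shows this change on its own, so any expectation rests on thin evidence. Compound 1 carries the same (hydroxymethyl)carbonyl group and gives 100 nM, which points to a move toward a lower number in this assay, of a size near the edge of the scatter. The expected change is a 2.3-fold lower number from compound 2 to compound 3 (0.35 log units; beyond the scatter). For compound 3 the estimated value is 200 nM, with an expected range of 60 nM to 600 nM.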

Compound 3, half-maximal inhibitory concentration: 20 nM
For compound 3 the middle estimate is 10-fold (1.00 log units) above the measured one; the measured number lies below the stated range.
By their numbers in this assay, from the lowest: compound 3; then compound 1; then compound 2.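

In this assay the change from methoxymethyl to hydroxymethyl gives a 23-fold lower number from compound 2 to compound 3 (1.35 log units; beyond the scatter) on the shared core, a large step for the loss of a single heavy atom, the methyl carbon. For the compounds shown here, this is the first measured pair to show hydrogen in place of methyl on an oxygen on a saturated carbon on its own, and it shows that the number at this position depends strongly on that one methyl. Nothing measured here explains the size of this step.

The compounds shown leave open whether the same change gives a step of this size on the core of compound 1. They also leave open how an amine or a carboxylic acid at this end of the side chain, or a longer chain carrying the hydroxy, would compare with hydroxymethyl in this assay on this core.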